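A few compounds are considered here, and "the series" means these few. Any claim that something is new, unique, unknown or untested is made for them only; others in the source may bear on it.

In a functional assay on HeLa cells (Homo sapiens) for cytotoxicity, read by LDH release, with a stated time of 48 h (on this read-out lower numbers stand for stronger inhibition and higher numbers for weaker inhibition), three compounds have been measured so far. Compound 1 (`Cc1ccc(C(=O)c2cc(F)c(OCC(=O)NNC(=O)c3ccc(=O)oc3)c(Cl)c2)cc1`) gives 26900 nM, compound 2 (`Cn1cnc(C(=O)NNC(=O)COc2c(F)cc(C(=O)c3ccc(F)cc3)cc2Cl)c1`) gives 40900 nM, and compound 3 (`Cn1cnc(C(=O)NNC(=O)COc2c(F)cc(C(=O)c3ccc(Cl)cc3)cc2Cl)c1`) gives 54500 nM. Compound 3 thus stands level with compound 2 within the scatter, while its number lies beyond the scatter from that of compound 1.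

Compound 4 (`Cc1ccc(C(=O)c2cc(F)c(OCC(=O)NNC(=O)c3cn(C)cn3)c(Cl)c2)cc1`) has methyl in place of chloro on an aromatic carbon of compound 3, para to a large group, turning 4-chlorophenyl into 4-methylphenyl: methyl in place of chloro on an aromatic carbon. Among the compounds with values here, the only measured step at that place, chloro in place of fluoro, is a 1.3-fold higher number from compound 2 to compound 3 (0.12 log units; within the scatter), and it stays within the scatter. The 4-methylphenyl group already occurs in compound 1 at 26900 nM, yet that compound differs elsewhere as well, so it offers only a loose guide. No step beyond the scatter is therefore expected in this assay. The expected step is a 1.3-fold lower number from compound 3 to compound 4 (0.11 log units; within the scatter). For compound 4 the estimated value is 42000 nM, with an expected range from 21000 nM to 80000 nM.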

Compound 4, half-maximal inhibitory concentration: 10400 nM
For compound 4 the middle estimate is 4.0-fold (0.61 log units) above the measured one, outside the stated range (below it).
By their numbers in this assay, from the lowest: compound 4; then compounds 1, 2 and 3 (each within the scatter of the next, the first and the last beyond it).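

In this assay, this place on the 4-substituted phenyl ring proves sensitive to the group it carries: methyl in place of chloro gives a 5.2-fold lower number from compound 3 to compound 4 (0.72 log units; beyond the scatter), and methyl in place of fluoro gives a 3.9-fold lower number from compound 2 to compound 4 (0.59 log units; beyond the scatter), whereas the exchange between the two halogens gave only a 1.3-fold higher number from compound 2 to compound 3 (0.12 log units; within the scatter) and stayed within the scatter. The 4-methylphenyl group does not fix the number alone, since with that group held constant, the change at the carbonyl carbon, to the five-membered aromatic ring with 2 hetero atoms, gives a 2.6-fold lower number from compound 1 to compound 4 (0.41 log units; beyond the scatter). Nothing available explains these steps.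

The compounds shown leave open how the unsubstituted phenyl, 4-ethylphenyl, 4-methoxyphenyl or a 4-aminophenyl group would read at this place. They also leave open whether chloro to methyl gives a similar step in the core of compound 1.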